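The compounds below may be only part of what the source reports. "The series", "measured", "known", "first", "only" and "open" are said of these compounds alone.

Two compounds carry numbers in a functional assay on CCRF-CEM cells (Homo sapiens) for cytotoxicity, read by MTT assay, with a stated time of 72 h; a higher number here means a weaker inhibitor of growth, a lower number a stronger inhibitor of growth. Compound 1 `CCCCOC(=O)Nc1ccc([Se]C#N)cc1` gives 27900 nM in this assay. Compound 2 `Cc1ccc(OC(=O)Nc2ccc([Se]C#N)cc2)cc1` gives 44700 nM in this assay, and the gap between the two is within the scatter, so neither can be set apart from the other. Compound 3 `CCOC(=O)Nc1ccc([Se]C#N)cc1` differs from compound 1 by hydrogen in place of ethyl on a saturated chain carbon, two bonds along the chain from an oxygen next to a carbonyl group. Among the measured compounds shown here, no measured pair shows this change. Because compound 1 gives 27900 nM and the change is confined to the butyl chain, compound 3 is expected to stay near it, with a step of a 1.1-fold higher number from compound 1 to compound 3 (0.03 log units; within the scatter) of no size beyond the scatter. Compound 3 is therefore estimated at 30000 nM, between 12000 nM and 75000 nM.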

Compound 3, concentration for total growth inhibition: 39100 nM
Compound 3: middle estimate off by 1.3-fold (0.12 log units), on the low side, within the range that was stated.
By their numbers in this assay, from the lowest: compounds 1, 3 and 2 (each within the scatter of the next).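

In this assay, among the compounds shown here, going from butoxy to ethoxy gives a 1.4-fold higher number from compound 1 to compound 3 (0.15 log units; within the scatter) and so provides the first measured step at this position. Across this change, a hydrogen in place of ethyl on a saturated chain carbon, the two chains cannot be set apart. Nothing available bears on why they read alike. The compounds shown leave open whether a longer chain, such as octyloxy, or an amine at the end of the chain would read apart from compound 1.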